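A Fluoro for Methoxy Swap on the Benzyl Ring

The source may report more compounds than this note shows. Statements on the series, on what has been measured and on what is new or still open speak of the compounds shown alone.

Compound 1 `C#CCN(CCCCOc1ccc2ccc(=O)oc2c1)Cc1ccc(OC)cc1`: 1130 nM
Compound 2 `C#CCN(CCCCOc1ccc2ccc(=O)oc2c1)Cc1cccc(OC)c1`: 2340 nM
Compound 3 `C#CCN(CCCOc1ccc2ccc(=O)oc2c1)Cc1ccc(C)cc1`: 7380 nM

In an assay on isolated protein for inhibition of Amine oxidase [flavin-containing] B (Homo sapiens), read by fluorescence and Amplex Red, with stated times of 15 min and 20 min (a lower number here means a stronger inhibitor, a higher number a weaker inhibitor), compound 2 gives 2340 nM and stands second highest of the three numbers; compound 1 is nearest with 1130 nM, and compound 3 is furthest with 7380 nM. Compound 4 `C#CCN(CCCCOc1ccc2ccc(=O)oc2c1)Cc1cccc(F)c1` differs from compound 2 by fluoro in place of methoxy on an aromatic carbon. Going by the values given here, no measured step repeats this exchange. Among the compounds with values here, the only single-point step, a 2.1-fold higher number from compound 1 to compound 2 (0.32 log units; beyond the scatter), concerned the position of the methoxy and was modest, while compound 3 differs from the others in more than one place. Compound 4 is therefore expected to show no step beyond the scatter, a 1.1-fold higher number from compound 2 to compound 4 (0.03 log units; within the scatter), with an estimated value of 2500 nM, within 1000 nM to 6000 nM.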

Compound 4, half-maximal inhibitory concentration: 1550 nM
Compound 4: middle estimate off by 1.6-fold (0.21 log units), on the high side, within the range that was stated.
By their numbers in this assay, from the lowest: compounds 1, 4 and 2 (each within the scatter of the next, the first and the last beyond it); then compound 3.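

In this assay, fluoro in place of methoxy on this aromatic carbon gives no change that can be told from the scatter (a 1.5-fold lower number from compound 2 to compound 4 (0.18 log units; within the scatter)), although the group loses a heavy atom and its hydrogen-bond acceptor. The 3-fluorobenzyl compound also cannot be told apart from the 4-methoxybenzyl one (a 1.4-fold higher number from compound 1 to compound 4 (0.14 log units; within the scatter)). Nothing available explains why this exchange is so quiet. As far as these compounds go, whether chloro, a nitrile or an amine on the same carbon would stay as close remains open. So does how the 3-fluorobenzyl group behaves on a shorter chain.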